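Swapping Chloro for Hydroxy in Compound 2

This account rests on a few compounds, and the source may have more. Where it says the series, first, only, none or still open, it means among the compounds named here.

Measured so far:
compound 1 `COc1cc(/C=C/c2ccc(C3=C(c4ccc(O)cc4)C4CC(S(=O)(=O)Oc5ccccc5)C3O4)cc2)cc(OC)c1`, > 100000 nM
compound 2 `O=S(=O)(Oc1ccc(Cl)cc1)C1CC2OC1C(c1ccc(/C=C/c3cc(O)cc(O)c3)cc1)=C2c1ccc(O)cc1`, 17900 nM

In a functional assay on MCF7 cells (Homo sapiens) for antiproliferative activity, read by MTT assay, with a stated time of 72 h (on this read-out lower numbers stand for stronger inhibition and higher numbers for weaker inhibition), compound 1 gives a limit, > 100000 nM, not a number. Compound 2 gives 17900 nM, the only number shown, so there is no measured step against which to judge where it stands. Compound 3 `O=S(=O)(Oc1ccc(O)cc1)C1CC2OC1C(c1ccc(/C=C/c3cc(O)cc(O)c3)cc1)=C2c1ccc(O)cc1` differs from compound 2 by hydroxy in place of chloro on an aromatic carbon. Within the data shown here, no measured pair shows the effect of this change, so the step of a 1.1-fold lower number from compound 2 to compound 3 (0.05 log units; within the scatter) is expected to lie within the usual scatter, in no set direction. Compound 3 is therefore estimated at 16000 nM, with a likely range from 5000 nM to 50000 nM.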

Compound 3, half-maximal inhibitory concentration: 14100 nM
Beside the measured number, compound 3's estimate is 1.1-fold (0.05 log units) above it; measured number inside the range.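

In this assay, hydroxy in place of chloro on this aromatic carbon gives a 1.3-fold lower number from compound 2 to compound 3 (0.10 log units; within the scatter). This position therefore takes either group with no change that can be told from scatter, even though hydroxy adds a hydrogen-bond donor and a hydrogen-bond acceptor that chloro lacks. Nothing shown here gives a reason for this result. Going by these compounds, whether the same holds for an amine, a carboxylic acid or a methoxy group at this place on the ring remains open.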